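This account rests on a few compounds, and the source may have more. Where it says the series, first, only, none or still open, it means among the compounds named here.

In an assay on BTI cells for inhibition of Amine oxidase [flavin-containing] B (Homo sapiens), read by fluorescence and Amplex Red, with a stated time of 15 min (on this read-out higher numbers stand for weaker inhibition and lower numbers for stronger inhibition), the measured compounds are:
compound 1 `C#CCN(C)CCCCOc1ccc2c(c1)OCCC2=O`, 58.9 nM
compound 2 `C#CCN(C)CCCCCOc1ccc2c(c1)OCCC2=O`, 4 nM
compound 3 `C#CCN(C)CCCCOc1ccc(C(C)=O)cc1OC`, 1150 nM

Compound 2 differs from compound 1 by (methyl(propargyl)amino)methyl in place of methyl(propargyl)amino on a saturated chain carbon, four bonds along the chain from an oxygen on an aromatic ring, and that change gave a 15-fold lower number from compound 1 to compound 2 (1.17 log units; beyond the scatter). Compound 4 `C#CCN(C)CCCCCOc1ccc(C(C)=O)cc1OC` has not yet been measured. It differs from compound 3 by (methyl(propargyl)amino)methyl in place of methyl(propargyl)amino on a saturated chain carbon, four bonds along the chain from an oxygen on an aromatic ring, which is the same change at the same place. Compound 3 sits on a different core from compound 1, and the difference between the two cores is not broken down here. Compound 3 gives the highest number among the three measured compounds in this assay. The expected step from compound 3 to compound 4 is a 13-fold lower number from compound 3 to compound 4 (1.11 log units; beyond the scatter), resting on the earlier step of a 15-fold lower number from compound 1 to compound 2 (1.17 log units; beyond the scatter), with a wider margin since the core differs. Compound 4 is therefore expected to give about 90 nM in this assay, estimated between 25 nM and 350 nM.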

Compound 4, half-maximal inhibitory concentration: 6520 nM
For compound 4 the middle estimate is 72-fold (1.86 log units) below the measured one; measured number outside the range, above it.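

Swapping methyl(propargyl)amino for (methyl(propargyl)amino)methyl does not carry over from the core of compound 1 to the core of compound 3 in this assay, where it gives a 5.7-fold higher number from compound 3 to compound 4 (0.75 log units; beyond the scatter). The two results run in opposite directions and lie clearly apart: the same change on two cores in this assay, a 15-fold lower number (1.17 log units; beyond the scatter) from compound 1 to compound 2 and a 5.7-fold higher number (0.75 log units; beyond the scatter) from compound 3 to compound 4, 83-fold (1.92 log units) apart, beyond the scatter of two such steps

So, in these two pairs, the outcome of this change depends on the core, but two pairs cannot show which part of the cores matters or predict the result on a third core.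

Open questions are how 2-(methyl(propargyl)amino)ethyl, a longer chain, would behave on each core, and whether a dimethylamino group in place of methyl(propargyl)amino would show the same split.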